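A Methoxy-to-Hydroxy Step Tested Against an Assay Limit

The compounds below may be only part of what the source reports. "The series", "measured", "known", "first", "only" and "open" are said of these compounds alone.

Compound 1 `O=C(Nc1cccc(-n2cc(-c3ccncc3)c(-c3ccc(Cl)c(O)c3)n2)c1)Nc1cccc(C(F)(F)F)c1` and compound 2 `COc1cc(-c2nn(-c3cccc(NC(=O)Nc4ccc(Cl)c(C(F)(F)F)c4)c3)cc2-c2ccncc2)ccc1Cl` share one core and differ only in their outer groups. In a functional assay on OVCAR-3 cells (Homo sapiens) for inhibition, read by sulforhodamine B assay, with a stated time of 48 h (a lower number here means that less compound is tolerated, a higher number that more compound is tolerated), compound 1 gives > 32500 nM, which is a limit and not a number. In this assay compound 2 gives > 32500 nM, again a limit rather than a number. Compound 2 thus stands at the limit of > 32500 nM in this assay, at which 2 of the 2 values shown sit, with nothing to rank it. Compound 3 `O=C(Nc1cccc(-n2cc(-c3ccncc3)c(-c3ccc(Cl)c(O)c3)n2)c1)Nc1ccc(Cl)c(C(F)(F)F)c1` differs from compound 2 by hydrogen in place of methyl on an oxygen on an aromatic ring. With both measured compounds at the limit, the expected step that the limit leaves unreadable from compound 2 to compound 3 is none beyond the scatter. Compound 3 is estimated at 40000 nM, within 15000 nM to 110000 nM, and is expected most likely to be reported as a limit again.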

Compound 3, concentration lethal to 50% of the cells: > 32500 nM
Compound 3 ended at the assay's limit; the forecaster's own chance of this, stated with the estimate: 75%; the middle value does not contradict the limit.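

In this assay, no step can be read among compound 1, compound 2 and compound 3, as each result is a limit and not a number: the limit of > 32500 nM in this assay, at which 3 of the 3 values shown sit.

The compounds shown leave open whether methoxy to hydroxy, or chloro in place of hydrogen, changes this read-out at all.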